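This account rests on a few compounds, and the source may have more. Where it says the series, first, only, none or still open, it means among the compounds named here.

Measured compounds:
compound 1, `CS(=O)(=O)c1ccc(N2N=C(c3ccc(-c4ccccc4)cc3)CCC2=O)cc1`, 6.6%
compound 2, `COc1ccc(C2=NN(c3ccc(S(C)(=O)=O)cc3)C(=O)CC2)cc1OC`, 66.6%

Compound 1 stands at the lowest of the two numbers obtained in a functional assay on the whole organism (strain Wistar) for inhibition, with Rattus norvegicus as the target, read by paw edema, with stated times of 30 min and 3 h, at a dose of 0.05 mmol/kg by the oral route; on this read-out lower numbers stand for less inhibition and higher numbers for more inhibition at the one dose given (going by the name of the read-out). Among the compounds with values here, its only neighbour is compound 2, which in this assay gives 66.6%, a number that lies well beyond the scatter above the value of compound 1; the two structures differ in more than one place, so their two values are all that can be said of them together.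

Compound 3, `CS(=O)(=O)c1ccc(N2N=C(c3ccc(F)cc3)CCC2=O)cc1`, has not yet been measured in this assay. It differs from compound 1 in one place only: fluoro in place of phenyl on an aromatic carbon. Within the data shown here, no step between measured compounds matches this change, so no measured step supports a forecast. Compound 1 gives the lower of the two numbers measured, and compound 2, carrying smaller groups on its aromatic ring, gives the far higher number, so compound 3 is expected to move upward from compound 1 by a number 31.4 percentage points higher from compound 1 to compound 3 (beyond the scatter), a step beyond the scatter. The estimate for compound 3 in this assay is 38%, within a range from 10% to 68%.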

Compound 3, a percentage reported as inhibition, in the whole organism at one dose (the size of the read-out at that dose, not a potency): 60%
Compound 3: the middle estimate sits 22 percentage points below what was measured, and the stated range covers the measured number.
By their numbers in this assay, from the lowest: compound 1; then compounds 3 and 2 (each within the scatter of the next).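

In this assay, putting fluoro in place of phenyl on an aromatic carbon, para to a large group, gives a number 53.4 percentage points higher from compound 1 to compound 3 (beyond the scatter), a large step. This single change shows that this one position can decide much of the read-out at the one oral dose given: with the rest of compound 1 left as it is, replacing a six-carbon aromatic ring with a single fluorine atom moves the number well beyond the scatter, something the two earlier values, from structures that differ in more than one place, could not show. Nothing available here bears on why the step is so large, so it can be recorded but not explained.

As far as these compounds go, whether a chloro, a carboxylic acid or an amine at this same position would give a number closer to that of compound 1 or to that of compound 3 remains open. From the compounds shown here alone, with only one dose reported, it also remains open whether a step of this size would hold at other doses.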